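This account rests on a few compounds, and the source may have more. Where it says the series, first, only, none or still open, it means among the compounds named here.

Compound 1 `CSc1ccc2c(c1)c(O)c(C(=O)N(C)C1CCCCC1)c(=O)n2C` gives 43% in a functional assay on the whole organism for inhibition, with Mus musculus as the target, at a dose of 32 mg/kg by the oral route; on this read-out lower numbers stand for less inhibition and higher numbers for more inhibition at the one dose given (going by the name of the read-out). Compound 2 `CSc1ccc2c(c1)c(O)c(C(=O)N(C)c1ccc(F)cc1)c(=O)n2C` gives 100%, the higher of the two numbers, the step of a number 57 percentage points higher from compound 1 to compound 2 (beyond the scatter) lying beyond the scatter. Compound 3 `CSc1ccc2c(c1)c(O)c(C(=O)N(C)c1ccc(C)cc1)c(=O)n2C` is not yet measured; the change methyl in place of fluoro on an aromatic carbon keeps the aryl on the amide-type nitrogen and alters only its substituent. For the measured compounds named here, the only measured step, a number 57 percentage points higher from compound 1 to compound 2 (beyond the scatter), swapped a ring rather than a ring substituent, so it bears little on this change; no step at that aromatic carbon has been measured. A step within the scatter, or none, is expected: a number 8 percentage points lower from compound 2 to compound 3 (within the scatter). Compound 3 is therefore estimated at 92%, with a range of 72% to 100%.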

Compound 3, a percentage reported as inhibition, in the whole organism at one dose (the size of the read-out at that dose, not a potency): 100%
Beside the measured number, compound 3's estimate is 8 percentage points below it; the measured number falls inside the stated range.
By their numbers in this assay, from the lowest: compound 1; then compounds 2 and 3 (each within the scatter of the next).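

Fluoro and methyl are interchangeable at this aromatic carbon, para to a large group: in this assay the change gives no change at the digits printed from compound 2 to compound 3 (within the scatter) and so leaves the read-out at this dose intact. The gain over cyclohexyl now holds for a second aryl group, with 4-methylphenyl giving a number 57 percentage points higher from compound 1 to compound 3 (beyond the scatter) and matching the step seen with 4-fluorophenyl. No measured evidence bears on the reason for either step.

For the compounds shown here, the single dose gives compound 2 and compound 3 the same printed number and does not separate them. On these data alone, whether an amine, a carboxylic acid or a longer chain at this aromatic carbon keeps the inhibition remains open.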